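Triazole aryl swap on the shared core: compound 4

A few compounds are considered here, and "the series" means these few. Any claim that something is new, unique, unknown or untested is made for them only; others in the source may bear on it.

Compound 2 `Cc1c(O)ccc2c1[C@H](Cn1cc(-c3ccc(F)cc3)nn1)[C@@]13CC(=O)[C@@](C)(CC[C@@H]21)C3` gives in a functional assay on SW480 cells (Homo sapiens) for cytotoxicity, read by MTT assay, with a stated time of 4 days (a lower number here means a stronger inhibitor, a higher number a weaker inhibitor), only a limit, > 20000 nM. Compound 1 `COc1ccc(-c2cn(C[C@H]3c4c(ccc(O)c4C)[C@@H]4CC[C@@]5(C)C[C@]43CC5=O)nn2)cc1` likewise shows only a limit in this assay, > 20000 nM. Compound 3 `C=C1C[C@]23C[C@@]1(O)CC[C@@H]2c1cccc(C)c1[C@@H]3Cn1cc(-c2ccc(Cl)cc2)nn1` also sits at a limit in this assay, > 20000 nM. Going by the values given here, the one step between measured neighbours that differ in a single place, a step that the two limits leave unreadable from compound 1 to compound 2, is therefore not readable in size; all that the numbers show is the limit of > 20000 nM in this assay, at which 3 of the 3 values shown sit. Compound 4 `Cc1c(O)ccc2c1[C@H](Cn1cc(-c3ccccn3)nn1)[C@@]13CC(=O)[C@@](C)(CC[C@@H]21)C3` differs from compound 2 by pyridin-2-yl in place of 4-fluorophenyl on an aromatic carbon. Among the compounds with values here, no measured step gives a readable size for a change of the group on the five-membered aromatic ring, so no direction can be taken from the series, and the expectation rests only on three values that all stopped at the limit. Compound 4 is therefore expected near 30000 nM in this assay, within 8000 nM to 100000 nM. The step that the limit leaves unreadable from compound 2 to compound 4 is expected to stay unreadable, most likely as another limit.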

Compound 4, half-maximal inhibitory concentration: > 20000 nM
Compound 4: only a limit was reported; the forecaster's own chance of this, stated with the estimate: 85%; the middle value does not contradict the limit.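

Compound 4 gives only a limit in this assay, > 20000 nM, so the steps to it from compound 1 and compound 2 cannot be read in size. Left open is whether any group on the five-membered aromatic ring of the shared core gives a readable value: the limit of > 20000 nM in this assay, at which 4 of the 4 values shown sit.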